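This account rests on a few compounds, and the source may have more. Where it says the series, first, only, none or still open, it means among the compounds named here.

Among the measured compounds shown here, compound 2 `Cc1cccc(-c2nc(CN3CCC(C(=O)NCCCN4C[C@H](C)C[C@H](C)C4)CC3)c(C)o2)c1` stands highest of the two numbers measured so far: in a physicochemical assay for permeability, using PAMPA (on this read-out higher numbers stand for higher permeability and lower numbers for lower permeability), compound 2 gives 279 10^-6 cm/s, while compound 1 `CC[C@@H]1C[C@H](CC)CN(CCCNC(=O)C2CCN(Cc3nc(-c4c(F)cccc4F)oc3C)CC2)C1` gives 130 10^-6 cm/s in this assay, a gap beyond the usual scatter. Compound 3 `Cc1cc(C)cc(-c2nc(CN3CCC(C(=O)NCCCN4C[C@H](C)C[C@H](C)C4)CC3)c(C)o2)c1` differs from compound 2 in one place (methyl in place of hydrogen on an aromatic carbon), the 3-methylphenyl becoming a 3,5-dimethylphenyl. For the measured compounds named here, no measured pair shows this change, so the step is expected to be small, upward if anything, and possibly within the scatter. The estimate for compound 3 in this assay is 320 10^-6 cm/s, ranging from 200 10^-6 cm/s to 500 10^-6 cm/s. That estimate means an expected step of a 1.1-fold higher number from compound 2 to compound 3 (0.06 log units; within the scatter).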

Compound 3, apparent permeability: 864 10^-6 cm/s
Beside the measured number, compound 3's estimate is 2.7-fold (0.43 log units) below it; the measured number lies above the stated range.
By their numbers in this assay, from the lowest: compound 1; then compound 2; then compound 3.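

In this assay, the step to 3,5-dimethylphenyl gives a 3.1-fold higher number from compound 2 to compound 3 (0.49 log units; beyond the scatter), so this aromatic carbon, meta to a large group and meta to a methyl group, is a place where one added methyl moves the read-out beyond the scatter. Among the compounds shown here, this is the first single-place step, since compound 1 and compound 2 differ in more than one place. No measurement shown here accounts for the size of this step. As far as these compounds go, it remains open whether a methoxy group or a chlorine atom on the same aromatic carbon would give a step of similar size.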